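Two Aromatic Swaps Already Lost, a Third Is Tested

This account rests on a few compounds, and the source may have more. Where it says the series, first, only, none or still open, it means among the compounds named here.

For the measured compounds named here, compound 1 `Fc1cccc(-c2nc(Nc3ccc(Cl)cc3)c3cc(F)ccc3n2)c1` is the only member of this small set with an actual number: in a functional assay on COLO 205 cells (Homo sapiens) for cytotoxicity, read by MTT assay, with a stated time of 48 h (a higher number here means a weaker inhibitor, a lower number a stronger inhibitor), compound 1 gives 32600 nM. Compound 2 `Fc1cccc(-c2nc(Nc3cccc(Cl)c3)c3cc(F)ccc3n2)c1` reaches only the limit of the assay, > 50000 nM. Compound 3 `Cc1ccc(Nc2nc(-c3cccc(F)c3)nc3ccc(F)cc23)cc1` likewise sits at the limit, > 50000 nM. Thus an at least 1.5-fold higher number from compound 1 to compound 2 (0.18 log units; that floor lies within the scatter) and an at least 1.5-fold higher number from compound 1 to compound 3 (0.18 log units; that floor lies within the scatter), while a step that the two limits leave unreadable from compound 2 to compound 3. Compound 4 `Cc1ccccc1Nc1nc(-c2cccc(F)c2)nc2ccc(F)cc12` differs from compound 1 by 2-methylphenyl in place of 4-chlorophenyl on a nitrogen on an aromatic ring. Since compound 2 and compound 3, each altered only in the phenyl on the nitrogen, both sit at the limit of > 50000 nM in this assay, at which 2 of the 3 values shown sit, a weakening is expected here as well, a 1.8-fold higher number from compound 1 to compound 4 (0.26 log units; within the scatter). Compound 4 is expected to give about 60000 nM in this assay, most likely somewhere between 25000 nM and 150000 nM.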

Compound 4, half-maximal inhibitory concentration: > 50000 nM
Compound 4 ended at the assay's limit (the forecaster's own chance of this, stated with the estimate: 65%); the middle value does not contradict the limit.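

With 2-methylphenyl on this nitrogen, compound 4 also stops at the limit of this assay, > 50000 nM. The replacement of 4-chlorophenyl gives an at least 1.5-fold higher number from compound 1 to compound 4 (0.18 log units; that floor lies within the scatter), so even this floor does not establish a real loss. The steps among compound 2, compound 3 and compound 4 cannot be read, but a methyl group in a second place on the phenyl adds another compound without a number: the limit of > 50000 nM in this assay, at which 3 of the 4 values shown sit.

From the compounds shown here alone, the true values of these three compounds remain open. So does whether an amine or a carboxylic acid on this phenyl would give a measurable number.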